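Sulfonylacetic acid phenoxymethyl biaryls: lengthening the alkoxy chain

The source may report more compounds than this note shows. Statements on the series, on what has been measured and on what is new or still open speak of the compounds shown alone.

Measured so far:
compound 1, `COc1cc(C)c(-c2cccc(COc3ccc4c(c3)SCC4CC(=O)O)c2)c(C)c1`, 123 nM
compound 2, `COc1cc(C)c(-c2cccc(COc3ccc4c(c3)C(O)CC4CC(=O)O)c2)c(C)c1`, 550 nM
compound 3, `CCOc1cc(C)c(-c2cccc(COc3ccc(S(=O)(=O)CC(=O)O)cc3)c2)c(C)c1`, 63.1 nM

In a functional assay on CHO cells for agonist activity at Free fatty acid receptor 1 (Homo sapiens), read by FLIPR and calcium flux (a higher number here means that more compound is needed for the effect, a lower number that less compound is needed), compound 3 gives the lowest number of the three. Compound 1 sits within the scatter of compound 3, whereas compound 2 lies clearly beyond it. Compound 4 `Cc1cc(OCCCS(C)(=O)=O)cc(C)c1-c1cccc(COc2ccc(S(=O)(=O)CC(=O)O)cc2)c1` differs from compound 3 by (methylsulfonyl)methyl in place of hydrogen on a saturated chain carbon, two bonds along the chain from an oxygen on an aromatic ring. Among the compounds with values here, no pair of measured compounds shows a step of this kind, so nothing says how this assay answers it. The expected step is a 1.2-fold higher number from compound 3 to compound 4 (0.08 log units; within the scatter), small, without a settled direction and not beyond the scatter. Compound 4 is therefore estimated at 75 nM, with a range from 25 nM to 220 nM.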

Compound 4, half-maximal effective concentration: 170 nM
Beside the measured number, compound 4's estimate is 2.3-fold (0.36 log units) below it, within the range that was stated.
By their numbers in this assay, from the lowest: compounds 3, 1 and 4 (each within the scatter of the next, the first and the last beyond it); then compound 2.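

Read in this assay the change from ethoxy to 3-(methylsulfonyl)propoxy gives a 2.7-fold higher number from compound 3 to compound 4 (0.43 log units; beyond the scatter) and is the first step measured at this position. The position therefore responds to the change, yet it accepts a 3-(methylsulfonyl)propoxy group at a modest cost rather than a collapse in the number. Nothing measured here accounts for the step.

Within the data shown here, the single step does not separate the longer chain from its methylsulfonyl end. A plain propoxy chain, or an amine or hydroxyl at the same chain end, would bear on that question.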